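A few compounds are considered here, and "the series" means these few. Any claim that something is new, unique, unknown or untested is made for them only; others in the source may bear on it.

Measured so far in an assay on microsomes from brain for inhibition of Fatty-acid amide hydrolase 1 (Rattus norvegicus), read by fluorescence and HPLC, with a stated time of 60 min; a higher number here means a weaker inhibitor, a lower number a stronger inhibitor:
compound 1, `CCCCCCCCc1ccc(OCC(=O)Cn2nnnc2SC)cc1`: 22 nM
compound 2, `CCCCCCCCc1ccc(OCC(=O)Cn2nnnc2-c2ccncc2)cc1`: 190 nM

Compound 2 holds the highest number of the two measured values; the nearest is compound 1, and the step of an 8.6-fold higher number from compound 1 to compound 2 (0.94 log units; beyond the scatter) came with pyridin-4-yl in place of methylsulfanyl on an aromatic carbon, a modest step beyond the scatter.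

Compound 3, `CCCCCCCCc1ccc(OCC(=O)Cn2nnnc2-c2cccnc2)cc1`, is not yet measured. It differs from compound 2 by pyridin-3-yl in place of pyridin-4-yl on an aromatic carbon; the two have the same atoms, joined differently, and the change sits on an aromatic carbon of a five-membered aromatic ring with 4 nitrogen. For the measured compounds named here, no measured step matches this change. Going by the values given here, the single step known, an 8.6-fold higher number from compound 1 to compound 2 (0.94 log units; beyond the scatter), exchanges one group for another of different atoms, so it bears on the present case only loosely, showing that a pyridyl group at this place is carried with a modest loss. With nothing pointing either way, compound 3 is expected to stand close to compound 2 in this assay, with a 1.3-fold lower number from compound 2 to compound 3 (0.10 log units; within the scatter) not beyond the scatter. The estimate for compound 3 is 150 nM, with a range of 50 nM to 500 nM.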

Compound 3, half-maximal inhibitory concentration: 190 nM
For compound 3 the middle estimate is 1.3-fold (0.10 log units) below the measured one; low and high end bracket the measured number.
By their numbers in this assay, from the lowest: compound 1; then compounds 2 and 3 (each within the scatter of the next).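

In this assay, exchanging pyridin-4-yl for pyridin-3-yl on the aromatic carbon of the five-membered aromatic ring with 4 nitrogen gives no change at the digits printed from compound 2 to compound 3 (within the scatter), so the two pyridyl isomers cannot be told apart at this place in the series. The replacement of methylsulfanyl by pyridin-3-yl gives an 8.6-fold higher number from compound 1 to compound 3 (0.94 log units; beyond the scatter), matching an 8.6-fold higher number from compound 1 to compound 2 (0.94 log units; beyond the scatter) for pyridin-4-yl, so the loss relative to methylsulfanyl is seen with both pyridyl groups and does not depend on which of these two isomers is present. No measurement is available that bears on the origin of this loss or of the match between the isomers.

The compounds shown leave open whether pyridin-2-yl, or a phenyl group with no ring nitrogen at all, would stand with compound 2 and compound 3 or would differ from them. They also leave open whether a longer sulfur-linked chain such as ethylsulfanyl, or a methoxy group in place of methylsulfanyl, would keep the value of compound 1 or move towards those of the pyridyl compounds.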